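A few compounds are considered here, and "the series" means these few. Any claim that something is new, unique, unknown or untested is made for them only; others in the source may bear on it.

In a functional assay, read by spectrophotometry, with a stated time of 30 min (a lower number here means a stronger inhibitor, a higher number a weaker inhibitor), compound 3 (`CC(C)(C)c1cc(/C=C/C(=O)NCCC2CCN(Cc3ccc(F)cc3)CC2)cc(C(C)(C)C)c1O`) gives 57500 nM. This is within the usual scatter of compound 1 (`Cc1ccccc1CN1CCC(CCNC(=O)/C=C/c2cc(C(C)(C)C)c(O)c(C(C)(C)C)c2)CC1`) at 65300 nM and compound 2 (`CC(C)(C)c1cc(/C=C/C(=O)NCCC2CCN(Cc3ccccc3F)CC2)cc(C(C)(C)C)c1O`) at 55900 nM, so the three stand level. Compound 4 (`CC(C)(C)c1cc(/C=C/C(=O)NCCC2CCN(Cc3cccc(Cl)c3)CC2)cc(C(C)(C)C)c1O`) carries 3-chlorophenyl in place of 4-fluorophenyl on a saturated chain carbon bound to an amine nitrogen in a ring. Earlier changes at this place were small, with a 1.1-fold lower number from compound 1 to compound 3 (0.06 log units; within the scatter), a 1.0-fold higher number from compound 2 to compound 3 (0.01 log units; within the scatter) and a 1.2-fold lower number from compound 1 to compound 2 (0.07 log units; within the scatter). Within the data shown here, none of the measured compounds carries chlorine, so this guide is indirect. No step beyond the scatter is expected in this assay. The estimated step is a 1.1-fold lower number from compound 3 to compound 4 (0.04 log units; within the scatter). Compound 4 is expected at 52000 nM, within an estimated range of 27000 nM to 95000 nM.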

Compound 4, half-maximal inhibitory concentration: 83100 nM
Compound 4: the middle estimate sits 1.6-fold (0.20 log units) below what was measured, and the stated range covers the measured number.
By their numbers in this assay, from the lowest: compounds 2, 3, 1 and 4 (each within the scatter of the next).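

In this assay, 3-chlorophenyl on a saturated chain carbon bound to an amine nitrogen in a ring stays level with the earlier groups (a 1.4-fold higher number from compound 3 to compound 4 (0.16 log units; within the scatter); a 1.5-fold higher number from compound 2 to compound 4 (0.17 log units; within the scatter); a 1.3-fold higher number from compound 1 to compound 4 (0.10 log units; within the scatter)). Chlorine, new to this set, therefore brings no step beyond the scatter, and all four compounds stand level. Nothing available explains these small differences.

Still open, going by these compounds, is whether a carboxylic acid or a longer chain in place of the 3-chlorobenzyl would step beyond the scatter.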